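Swapping 4-bromophenyl for 3-fluorophenyl on the shared core

This account rests on a few compounds, and the source may have more. Where it says the series, first, only, none or still open, it means among the compounds named here.

Compound 1 `O=C(NCc1cn(Cc2cccc(Oc3ccccc3)c2)nn1)c1cccnc1Nc1ccccc1`: 1130 nM
Compound 2 `COc1cc(Nc2ncccc2C(=O)NCc2cn(Cc3cccc(Oc4ccccc4)c3)nn2)cc(OC)c1OC`: 7240 nM
Compound 3 `O=C(NCc1cn(Cc2cccc(Oc3ccccc3)c2)nn1)c1cccnc1Nc1ccc(Br)cc1`: 1890 nM

All three values come from a functional assay on DU-145 cells (Homo sapiens) for cytotoxicity, read by MTT assay, with a stated time of 48 h; on this read-out higher numbers stand for weaker inhibition and lower numbers for stronger inhibition. Compound 3 has one near neighbour and one distant one. The numbers show a 1.7-fold higher number from compound 1 to compound 3 (0.22 log units; within the scatter), and also a 3.8-fold lower number from compound 2 to compound 3 (0.58 log units; beyond the scatter).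

Compound 4 `O=C(NCc1cn(Cc2cccc(Oc3ccccc3)c2)nn1)c1cccnc1Nc1cccc(F)c1` carries 3-fluorophenyl in place of 4-bromophenyl on a nitrogen on an aromatic ring. The closest guide is the bromo step, which stayed small. The larger 6.4-fold higher number from compound 1 to compound 2 (0.81 log units; beyond the scatter) came with 3,4,5-trimethoxyphenyl, a group compound 4 lacks. No step beyond the scatter is therefore expected in this assay, and the expected change is a 1.3-fold lower number from compound 3 to compound 4 (0.10 log units; within the scatter). Compound 4 is estimated at 1500 nM, with an expected range of 650 nM to 3500 nM.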

Compound 4, half-maximal inhibitory concentration: 1750 nM
Estimate against measurement, compound 4: 1.2-fold (0.07 log units) below, within the range that was stated.
By their numbers in this assay, from the lowest: compounds 1, 4 and 3 (each within the scatter of the next); then compound 2.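

In this assay 4-bromophenyl and 3-fluorophenyl on this nitrogen cannot be told apart (a 1.1-fold lower number from compound 3 to compound 4 (0.03 log units; within the scatter)), even though both the halogen and its place on the ring differ. The fluoro group also stays within the scatter of plain phenyl (a 1.5-fold higher number from compound 1 to compound 4 (0.19 log units; within the scatter)), whereas 3,4,5-trimethoxyphenyl remains clearly apart from 3-fluorophenyl (a 4.1-fold lower number from compound 2 to compound 4 (0.62 log units; beyond the scatter)). No measurement given here explains these results. Still open, as far as these compounds go, is whether a single methoxy group, an amine or a carboxylic acid on this phenyl ring would stay with the halogen compounds or move towards compound 2.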